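This account rests on a few compounds, and the source may have more. Where it says the series, first, only, none or still open, it means among the compounds named here.

Compound 1 `COc1cc(Br)cc(/C=C/C(=O)c2ccc(C)cc2)c1O` reaches 148% in an ADME assay on MCF-10A cells (Homo sapiens) for cytotoxicity, read by sulforhodamine B assay, with a stated time of 72 h, tested at 30 uM; a higher number here means a stronger effect of the compound at the concentration tested, a lower number a weaker effect. Compound 2 `Cc1ccc(C(=O)/C=C/c2cc(Br)ccc2O)cc1` gives 49.4% in this assay, a step of a number 98.6 percentage points lower from compound 1 to compound 2 (beyond the scatter) for the change (hydrogen in place of methoxy on an aromatic carbon). Compound 3 `COc1cccc(C(=O)CC2C(C#N)=C(N)Oc3c(OC)cc(Br)cc32)c1` gives 46.3% in this assay; how its core differs from that of compound 1 is not broken down here. Compound 4 `COc1cccc(C(=O)CC2C(C#N)=C(N)Oc3ccc(Br)cc32)c1` is to be measured; it carries the same kind of change, (hydrogen in place of methoxy on an aromatic carbon), but the place is not the same: in compound 1 the carbon is ortho to a hydroxy group and meta to a large group, whereas in compound 3 it is part of a fused or bridged system of two rings, ortho and meta to a fused ring. A step of a number 11.3 percentage points lower from compound 3 to compound 4 (beyond the scatter) is expected for compound 4, far smaller than the earlier one, because compound 3 already stands at 46.3% and little room for a drop of that size remains. Compound 4 is estimated at 35%, between 10% and 60%.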

Compound 4, a percentage reported as activity, at one concentration (the size of the read-out at that concentration, not a potency): 43.7%
Compound 4: middle estimate off by 8.7 percentage points, on the low side, and the stated range covers the measured number.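

The change of methoxy to hydrogen on an aromatic carbon gives a number 2.6 percentage points lower from compound 3 to compound 4 (within the scatter) in this assay, so on this core the methoxy group makes no readable difference. The step seen on the core of compound 1 therefore does not carry over to the core of compound 3: the same change on two cores in this assay, a number 98.6 percentage points lower (beyond the scatter) from compound 1 to compound 2 and a number 2.6 percentage points lower (within the scatter) from compound 3 to compound 4, 96 percentage points apart, beyond the scatter of two such steps This rests on one pair per core, and it does not show which feature of the two cores separates the steps, nor how the change would behave on any third core.

Still open, on these data alone, is whether an amine, a carboxylic acid or a longer alkoxy chain at this place would shift the number on either core. Also open, as far as these compounds go, is whether the methoxy group is unique in the core of compound 1.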